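This account rests on a few compounds, and the source may have more. Where it says the series, first, only, none or still open, it means among the compounds named here.

The measured compounds:
Compound 1, `COc1cc2c(Oc3ccc(NC(=O)c4nn(-c5ccccc5)c(=O)cc4C)cc3F)ccnc2cc1OCCCN1CCN(C)CC1`: 350 nM
Compound 2, `COc1cc2c(Oc3ccc(NC(=O)c4nn(-c5ccccc5C(F)(F)F)c(=O)cc4C)cc3F)ccnc2cc1OCCCN1CCCCC1`: 140 nM

Both values come from a functional assay on A549 cells (Homo sapiens) for inhibition, read by MTT assay, with a stated time of 72 h; a lower number here means a stronger inhibitor, a higher number a weaker inhibitor. Compound 2 gives the lower of the two numbers, and compound 1 sits at a higher number, by a margin beyond the usual scatter of repeated measurements. For the measured compounds named here, compound 1 and compound 2 differ from each other in more than one place, so their two values show only that compound 2 is the stronger inhibitor of the pair, not which part of the structure accounts for that.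

Compound 3, `COc1cc2c(Oc3ccc(NC(=O)c4nn(-c5ccccc5C(F)(F)F)c(=O)cc4C)cc3F)ccnc2cc1OCCCN1CCN(C)CC1`, has not yet been measured. It keeps everything in compound 2 except one change: 4-methylpiperazin-1-yl in place of piperidin-1-yl on a saturated chain carbon, three bonds along the chain from an oxygen on an aromatic ring. Going by the values given here, the ring that enters is the one found in compound 1, so compound 3 shares one end of its structure with compound 1 and the other with compound 2. Among the compounds with values here, no measured pair isolates this ring swap, so its effect cannot be read from these data. The expected step from compound 2 to compound 3 is a 1.6-fold higher number from compound 2 to compound 3 (0.20 log units; within the scatter), meaning little change or a modest move toward a weaker inhibitor, close to the scatter. Compound 3 is estimated at 220 nM, with a likely range from 80 nM to 600 nM.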

Compound 3, half-maximal inhibitory concentration: 170 nM
For compound 3 the middle estimate is 1.3-fold (0.11 log units) above the measured one; the range from low to high includes it.
By their numbers in this assay, from the lowest: compounds 2 and 3 (each within the scatter of the next); then compound 1.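

In this assay, placing 4-methylpiperazin-1-yl instead of piperidin-1-yl on the saturated chain carbon, three bonds along the chain from an oxygen on an aromatic ring, gives a 1.2-fold higher number from compound 2 to compound 3 (0.08 log units; within the scatter) and so this pair cannot be told apart. With trifluoromethyl on the aromatic ring, this position therefore accepts either ring, and the second nitrogen of 4-methylpiperazin-1-yl brings no measurable gain or loss in this cell assay. With 4-methylpiperazin-1-yl held constant, trifluoromethyl in place of hydrogen on an aromatic carbon gives a 2.1-fold lower number from compound 1 to compound 3 (0.31 log units; beyond the scatter) and this modest step is the only single change shown here that moves the number beyond the scatter, though nothing measured alongside these cell results explains it.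

The compounds shown leave open whether the ring swap would stay as quiet in a compound with hydrogen in place of trifluoromethyl, and whether a morpholin-4-yl ring, a dimethylamino group or a longer chain would fit this position equally well. They also leave open whether a chlorine or a methoxy group could stand in for trifluoromethyl on that aromatic carbon.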